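This account rests on a few compounds, and the source may have more. Where it says the series, first, only, none or still open, it means among the compounds named here.

The compounds measured so far:
compound 1 `COc1ccccc1-c1ncnn1-c1cc(OC)c(OC)c(OC)c1` – > 10000 nM
compound 2 `COc1ccc(-n2ncnc2-c2cc(OC)c(OC)c(OC)c2)cc1` – > 10000 nM
compound 3 `CCOc1ccccc1-c1ncnn1-c1cc(OC)c(OC)c(OC)c1` – > 10000 nM

Compound 1 stands at a limit of the assay rather than at a number: in a functional assay on HeLa cells (Homo sapiens) for antiproliferative activity, read by MTT assay, with a stated time of 72 h (a lower number here means a stronger inhibitor, a higher number a weaker inhibitor), compound 1 gives > 10000 nM. Compound 2 gives the same limit in this assay, as does compound 3, so that (the limit of > 10000 nM in this assay, at which 3 of the 3 values shown sit). The only one-place step among these three, a step that the two limits leave unreadable from compound 1 to compound 3, is therefore unreadable.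

Compound 4 `COc1cc(-n2ncnc2-c2ccc(Cl)cc2)cc(OC)c1OC` is not yet measured. Its change from compound 1 is 4-chlorophenyl in place of 2-methoxyphenyl on an aromatic carbon. Within the data shown here, no measured step involves this change, and the one step that is known gives no size, so nothing in the data points to a readable gain or loss. The expectation for compound 4 rests only on the fact that every value shown sits at the limit; the estimated step of a number no higher from compound 1 to compound 4 (the limit leaves the size open) is therefore set at none beyond the scatter. Compound 4 is expected to give about 10000 nM in this assay, within 2500 nM to 40000 nM, with a fair chance that only a limit is reported again.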

Compound 4, half-maximal inhibitory concentration: > 10000 nM
Compound 4 gave a limit, no number; the forecaster's own chance of this, stated with the estimate: 65%; the middle value lies on the limit itself.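

In this assay compound 4 gives > 10000 nM, which is a limit, and compound 1 also stands at a limit, so the step between compound 1 and compound 4 cannot be read: the limit of > 10000 nM in this assay, at which 4 of the 4 values shown sit. The compounds shown leave open whether any change to the shared core moves the activity to a measurable number.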